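Swapping the aryl group on the piperazine of compound 2

The compounds below may be only part of what the source reports. "The series", "measured", "known", "first", "only" and "open" are said of these compounds alone.

Measured compounds:
- compound 1, `O=C1C2CCCCN2C(=O)N1CN1CCN(c2cccc(C(F)(F)F)c2)CC1`: > 1000 nM
- compound 2, `COc1ccccc1N1CCN(CCCN2C(=O)C3CCCCN3C2=O)CC1`: 9.9 nM

In an assay on isolated protein for binding affinity to Adrenergic receptor alpha-1 (Rattus norvegicus), read by radioligand binding (a higher number here means a weaker inhibitor, a lower number a stronger inhibitor), compound 2 gives 9.9 nM, the only numerical value among the two shown. Compound 1 reaches only a limit of the assay, > 1000 nM, as recorded in the limit of > 1000 nM in this assay, at which 1 of the 2 values shown sits. Compound 3, `O=C1C2CCCCN2C(=O)N1CCCN1CCN(c2cccc(C(F)(F)F)c2)CC1`, is not yet measured in this assay; it carries 3-(trifluoromethyl)phenyl in place of 2-methoxyphenyl on an amine nitrogen in a ring. Among the compounds with values here, no measured step isolates this change, so the size of the step from compound 2 to compound 3 is estimated as a loss in affinity beyond the scatter, a 15-fold higher number from compound 2 to compound 3 (1.18 log units; beyond the scatter). Compound 3 is therefore expected to give about 150 nM, likely between 30 nM and 800 nM.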

Compound 3, inhibition constant: 90.4 nM
Compound 3: middle estimate off by 1.7-fold (0.22 log units), on the high side; low and high end bracket the measured number.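

In this assay, within the data shown here, 3-(trifluoromethyl)phenyl in place of 2-methoxyphenyl on the amine nitrogen in the ring gives a 9.1-fold higher number from compound 2 to compound 3 (0.96 log units; beyond the scatter), the first measured step at this position. The change costs affinity, yet compound 3 still gives a measurable number. Compound 1, which carries the same 3-(trifluoromethyl)phenyl group on a different chain, stands at a limit of the assay: the limit of > 1000 nM in this assay, at which 1 of the 3 values shown sits.

The compounds shown do not separate losing the methoxy group from gaining trifluoromethyl. They also leave open how an unsubstituted phenyl or a 3-methoxyphenyl would read on the chain of compound 3.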